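Compound 2 to compound 4: same atoms, joined differently

A few compounds are considered here, and "the series" means these few. Any claim that something is new, unique, unknown or untested is made for them only; others in the source may bear on it.

In a functional assay on L1210 cells (Mus musculus) for inhibition, with a stated time of 96 h (on this read-out higher numbers stand for weaker inhibition and lower numbers for stronger inhibition), compound 1 `CCNCCCNCCCN` gives > 100000 nM, which is a limit of the assay. Compound 2 `CCNCCCNCCCCN` gives 4000 nM and compound 3 `CCNCCCCNCCCNCC` gives 700 nM. Compound 2 therefore holds the higher of the two actual numbers, and compound 3 is its nearest neighbour.

Compound 4 `NCCCCCNCCCCN` has the same atoms as compound 2, joined differently: 2-aminoethyl in place of ethylamino on a saturated chain carbon, three bonds along the chain from an amine nitrogen. The change lies on a saturated chain carbon, three bonds along the chain from an amine nitrogen.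

Two measured steps act at that place, both large: an at least 25-fold lower number from compound 1 to compound 2 (1.39 log units; beyond the scatter) and an at least 140-fold lower number from compound 1 to compound 3 (2.15 log units; beyond the scatter). Neither makes this exact exchange, so they give only loose guidance. A higher number is expected for compound 4 because the gain of ethyl on an amine nitrogen gave a 5.7-fold lower number from compound 2 to compound 3 (0.76 log units; beyond the scatter), a modest step, and compound 4 has no ethylamino.

The expected change is a 2.5-fold higher number from compound 2 to compound 4 (0.40 log units; beyond the scatter), a modest one. For compound 4 the estimated value is 10000 nM, within a range of 2000 nM to 50000 nM.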

Compound 4, half-maximal inhibitory concentration: 180 nM
Beside the measured number, compound 4's estimate is 56-fold (1.74 log units) above it; measured number outside the range, below it.
By their numbers in this assay, from the lowest: compound 4; then compound 3; then compound 2. At a limit, above all of these: compound 1.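

In this assay, among these compounds, the earlier steps at this place changed which atoms were present, whereas this one keeps them and only joins them differently: a 22-fold lower number from compound 2 to compound 4 (1.35 log units; beyond the scatter). So on a saturated chain carbon, three bonds along the chain from an amine nitrogen, the arrangement of the same atoms is enough for a large step, with ethylamino and 2-aminoethyl, read one bond further out as (ethylamino)methyl and 3-aminopropyl, not interchangeable. Nothing measured in the series gives a cause for this step.

The compounds shown leave open how the number responds to a longer chain at this place, such as 4-aminobutyl. They also leave open whether the amine of 2-aminoethyl is needed at all, which a hydroxyl in its place would test.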